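Pyrrolyl for phenyl in an anilide series

A few compounds are considered here, and "the series" means these few. Any claim that something is new, unique, unknown or untested is made for them only; others in the source may bear on it.

Measured compounds in a functional assay on A-375 cells (Homo sapiens) for antiproliferative activity; a lower number here means a stronger inhibitor, a higher number a weaker inhibitor:
compound 1 `O=C(Nc1ccc(-c2cscn2)cc1)C1CCN(Cc2ccc(F)c(F)c2)C1` gives 10000 nM
compound 2 `O=C(Nc1ccc(-c2cscn2)cc1)C1CCCN(Cc2cc(F)cc(F)c2)C1` gives 1360 nM
compound 3 `O=C(Nc1ccc(-c2ccccc2)cc1)C1CCCN(Cc2ccc(F)c(F)c2)C1` gives 2580 nM

Among the three numbers, compound 3 holds the second highest. Its nearest neighbour is compound 2, whose number is lower but within the usual scatter, so the two cannot be ordered with confidence. Compound 1 lies furthest from compound 3, with a higher number, and that gap is beyond the scatter. For the measured compounds named here, no pair of these measured compounds differs in only one place, so no single structural change is tied to a measured step.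

Compound 4 `O=C(Nc1ccc(-c2cc[nH]c2)cc1)C1CCCN(Cc2ccc(F)c(F)c2)C1` is the compound still to be measured. It differs from compound 3 in one place: 1H-pyrrol-3-yl in place of phenyl on an aromatic carbon. The rest of the shared core, the amide and the difluorobenzyl group, is unchanged.

Going by the values given here, nothing among the measured compounds isolates this exchange, so the expectation rests on the general spread of the numbers. The step in this assay from compound 3 is expected to be small, most likely within the scatter, with no direction set by the data; the expected step is a 1.2-fold higher number from compound 3 to compound 4 (0.07 log units; within the scatter). For compound 4 the estimated value in this assay is 3000 nM, within a range from 800 nM to 12000 nM.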

Compound 4, half-maximal inhibitory concentration: 1420 nM
Compound 4: middle estimate off by 2.1-fold (0.32 log units), on the high side; the range from low to high includes it.
By their numbers in this assay, from the lowest: compounds 2, 4 and 3 (each within the scatter of the next); then compound 1.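

In this assay, for the compounds shown here, the exchange of phenyl for 1H-pyrrol-3-yl on an aromatic carbon, para to a large group, gives the first step in this set tied to a single structural change: a 1.8-fold lower number from compound 3 to compound 4 (0.26 log units; within the scatter). At this position, then, a five-membered aromatic ring with 1 hetero atom and 1 hydrogen-bond donor can stand in place of a six-membered aromatic ring of carbon only with no change that can be separated from the usual scatter, so compound 3 and compound 4 cannot be ordered with confidence. The data offer no independent measurement that bears on this result, and no explanation for it can be drawn from them.

What the compounds shown leave open is whether any group at this position would produce a step beyond the scatter, for example a pyridine ring, a 1-methyl-1H-pyrrol-3-yl group or a carboxylic acid. Going by these compounds alone, they also leave open whether the exchange would give a similar step with a different benzyl group on the shared core, since this single pair carries only the one difluorobenzyl pattern.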